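This account rests on a few compounds, and the source may have more. Where it says the series, first, only, none or still open, it means among the compounds named here.

Compound 1 `N#C[C@@H]1CCCN1C(=O)[C@@H]1C[C@H](C(=O)N2CCCCC2)CN1` gives 84% in an assay on the whole organism (plasma, strain Sprague-Dawley) for inhibition of Dipeptidyl peptidase 4 (Rattus norvegicus), with a stated time of 6 h, at a dose of 1 mg/kg by the oral route; on this read-out higher numbers stand for more inhibition at the one dose given (going by the name of the read-out) and lower numbers for less inhibition. Compound 2 `CN(C)C(=O)[C@@H]1CN[C@H](C(=O)N2CCC[C@H]2C#N)C1` gives 76%. Compound 3 `C[C@@H]1N[C@H](C(=O)N2CCC[C@H]2C#N)C[C@@H]1C(=O)N1CCCCC1` gives 91%.

These three measured compounds and one further compound, compound 4 `C[C@@H]1N[C@H](C(=O)N2CCC[C@H]2C#N)C[C@@H]1C(=O)N(C)C`, which has not yet been measured, share a common core. Compound 3 differs from compound 1 only by methyl in place of hydrogen on a saturated ring carbon, and in this assay this gives a number 7 percentage points higher from compound 1 to compound 3 (within the scatter). Compound 4 stands to compound 3 exactly as compound 2 stands to compound 1: the change is dimethylamino in place of piperidin-1-yl on a carbonyl carbon, and it is the same change as dimethylamino in place of piperidin-1-yl on a carbonyl carbon, since the two place descriptions agree word for word. In the measured pair the step was a number 8 percentage points lower from compound 1 to compound 2 (within the scatter).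

Within the data shown here, compound 2 and compound 3 differ in two places at once, and no single step is broken down between them; their values simply show a gap beyond the scatter, compound 3 sitting higher in this assay.

For compound 4, the expectation rests on the one measured occurrence of this change. Because a number 8 percentage points lower from compound 1 to compound 2 (within the scatter) was within the scatter, a step of similar size is expected from compound 3, namely a number 8 percentage points lower from compound 3 to compound 4 (within the scatter). The estimate for compound 4 in this assay is therefore 83%, expected to lie between 70% and 93%. Among the measured compounds shown here, with only one earlier example of this change, the range is kept wide.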

Compound 4, a percentage reported as inhibition, in the whole organism at one dose (the size of the read-out at that dose, not a potency): 95%
Beside the measured number, compound 4's estimate is 12 percentage points below it; the whole stated range lies below it.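

In this assay, dimethylamino in place of piperidin-1-yl on a carbonyl carbon gave a number 4 percentage points higher from compound 3 to compound 4 (within the scatter), and the change carried from the core of compound 1 to the methyl-bearing core with no gap that can be told from the scatter: the same change on two cores in this assay, a number 8 percentage points lower (within the scatter) from compound 1 to compound 2 and a number 4 percentage points higher (within the scatter) from compound 3 to compound 4, 12 percentage points apart, within the scatter of two such steps. Methyl in place of hydrogen on a saturated ring carbon gave a number 19 percentage points higher from compound 2 to compound 4 (beyond the scatter), and this step likewise stays in line with its earlier occurrence: the same change on two cores in this assay, a number 7 percentage points higher (within the scatter) from compound 1 to compound 3 and a number 19 percentage points higher (beyond the scatter) from compound 2 to compound 4, 12 percentage points apart, within the scatter of two such steps. This shows that, among these four compounds, neither change read differently on the two cores, but each comparison rests on only two pairs and a single read-out at one dose, which is not a potency, and it does not show that either change would transfer to any other core.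

The compounds shown carry only piperidin-1-yl or dimethylamino on the carbonyl carbon and only hydrogen or methyl on the saturated ring carbon, leaving open how a morpholine or pyrrolidine amide, or an ethyl group on that ring carbon, would read in this assay. Also open, on these data alone, is whether other doses or times would separate compound 3 and compound 4.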